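The compounds below may be only part of what the source reports. "The series", "measured", "known", "first", "only" and "open" are said of these compounds alone.

Compound 1 `O=C(Nc1cc(-c2ccccc2)nn1-c1ccccc1)c1ccccc1`: 300 nM
Compound 2 `O=C(Nc1cc(-c2ccccc2)nn1-c1ccccc1)c1ccccn1`: 585 nM

Going by the values given here, in an assay on isolated protein with metabotropic glutamate receptor 5 (Rattus norvegicus) as the target (a higher number here means that more compound is needed for the effect, a lower number that less compound is needed), compound 2 gives 585 nM, and the only other measured compound, compound 1, lies within the scatter of it. Among the compounds with values here, the single measured step, a 2.0-fold higher number from compound 1 to compound 2 (0.29 log units; within the scatter), exchanged phenyl for pyridin-2-yl on the carbonyl carbon. Compound 3 `O=C(Nc1cc(-c2ccccc2)nn1-c1ccccc1)c1cnccn1` carries the change (pyrazin-2-yl in place of pyridin-2-yl on a carbonyl carbon). The earlier step also altered the ring on the carbonyl carbon and stayed within the scatter. A step of similar size, if any, is expected: a 1.4-fold higher number from compound 2 to compound 3 (0.14 log units; within the scatter). Compound 3 is estimated at 800 nM, with a range from 300 nM to 2200 nM.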

Compound 3, half-maximal effective concentration: 400 nM
For compound 3 the middle estimate is 2.0-fold (0.30 log units) above the measured one; measured number inside the range.
By their numbers in this assay, from the lowest: compounds 1, 3 and 2 (each within the scatter of the next).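

In this assay, pyrazin-2-yl on the carbonyl carbon gives a 1.5-fold lower number from compound 2 to compound 3 (0.17 log units; within the scatter) and a 1.3-fold higher number from compound 1 to compound 3 (0.12 log units; within the scatter), so a ring with 2 hetero atoms stays within the scatter of both earlier compounds. Across phenyl, pyridin-2-yl and pyrazin-2-yl at this position, the numbers therefore show no real separation. Nothing available explains this closeness. Still open, as far as these compounds go, is whether an amine or a longer alkyl chain on the carbonyl carbon would move the number beyond the scatter. Changes elsewhere on the shared core also remain untested here.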